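A few compounds are considered here, and "the series" means these few. Any claim that something is new, unique, unknown or untested is made for them only; others in the source may bear on it.

Measured so far:
compound 1, `OCc1ccc(-c2nn(Cc3cccnc3)c3ccccc23)o1` — 9600 nM
compound 2, `CC(C)(C)c1cnc(-c2nn(Cc3ccccc3F)c3ncccc23)nc1N` — 709000 nM

In a functional assay (aorta) with Oryctolagus cuniculus as the target (on this read-out lower numbers stand for stronger inhibition and higher numbers for weaker inhibition), compound 1 gives 9600 nM. In this assay compound 2 gives 709000 nM. Going by the values given here, compound 2 stands at the highest of the two numbers; its only neighbour is compound 1, whose number is far lower, a gap well beyond the scatter. Among the compounds with values here, the two compounds share no common substituent pattern that would let a single-change step be read off, so the set holds no measured step at all.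

Compound 3, `CSc1cnc(-c2nn(Cc3ccccc3F)c3ncccc23)nc1N`, is the next compound to be run in this assay. It differs from compound 2 in one place: methylsulfanyl in place of tert-butyl on an aromatic carbon. Nothing in the set tells how such a change moves the read-out, and compound 2 itself sits at a very weak level. The step from compound 2 to compound 3 is therefore expected to be small, with no clear direction and most likely none beyond the scatter, a 1.4-fold lower number from compound 2 to compound 3 (0.15 log units; within the scatter). Compound 3 is expected to give 500000 nM, with a range from 100000 nM to 2500000 nM.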

Compound 3, half-maximal inhibitory concentration: 243000 nM
Compound 3: the middle estimate sits 2.1-fold (0.31 log units) above what was measured; the measured number falls inside the stated range.
By their numbers in this assay, from the lowest: compound 1; then compound 3; then compound 2.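

In this assay, the aromatic carbon ortho to an amino group proves sensitive to its substituent: methylsulfanyl in place of tert-butyl gives a 2.9-fold lower number from compound 2 to compound 3 (0.47 log units; beyond the scatter), a modest move towards stronger inhibition but one beyond the scatter. Going by these compounds alone, this is the first single-place step, and it shows that this position can shift the read-out, which the unrelated pair of compound 1 and compound 2 could not show. The exchange alters several things at once, with 2 heavy atoms entering for 4, sulfur entering and a hydrogen-bond acceptor gained, and no supporting measurement is available to separate these changes or account for the shift.

Going by these compounds, with compound 3 at 243000 nM, it remains open whether methyl, methoxy, chlorine or an amine on this carbon would take the number lower still, and whether the sulfur atom matters at all. On these data alone, it is also open whether a longer chain on the sulfur, such as ethylsulfanyl, would keep the gain, as a single step gives no trend.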